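The source may hold more compounds than are shown below. What is called first, only, known or untested is meant among the compounds shown, and "the series" means these compounds.

Measured in an ADME assay for pharmacokinetics; on this read-out lower numbers stand for a shorter-lived compound and higher numbers for a longer-lived compound
- compound 1 `N=C(N)SCCOc1oc(=O)c2cc(NC(=O)CCc3ccccc3)ccc2c1Cl` gives 0.65 h
- compound 2 `CC(=O)Nc1ccc2c(Cl)c(OCCCSC(=N)N)oc(=O)c2c1` gives 1.13 h
- compound 3 `N=C(N)SCCCOc1oc(=O)c2cc(NC(=O)CCc3ccccc3)ccc2c1Cl` gives 1.1 h

Compound 3 at 1.1 h stands level with the other two, as both steps that reach it lie within the scatter. Compound 4 `N=C(N)SCCCOc1oc(=O)c2cc(NC(=O)Nc3ccccc3)ccc2c1Cl` is to be measured next and carries anilino in place of phenethyl on a carbonyl carbon, anilino in place of phenethyl on a carbonyl carbon. Going by the values given here, no measured step makes this exchange. The closest is a 1.0-fold lower number from compound 2 to compound 3 (0.01 log units; within the scatter), benzyl in place of hydrogen on a saturated chain carbon bound to a carbonyl carbon. The other, a 1.7-fold higher number from compound 1 to compound 3 (0.23 log units; within the scatter), concerns the chain on the oxygen and bears less. Neither points to a step beyond the scatter. The step expected is a 1.1-fold lower number from compound 3 to compound 4 (0.04 log units; within the scatter). For compound 4 the estimated value is 1 h, with an expected range of 0.55 h to 1.8 h.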

Compound 4, half-life: 2.47 h
For compound 4 the middle estimate is 2.5-fold (0.39 log units) below the measured one, outside the stated range (above it).
By their numbers in this assay, from the lowest: compounds 1, 3 and 2 (each within the scatter of the next); then compound 4.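

In this assay, this position on the carbonyl carbon is not indifferent to its substituent: anilino gives a 2.2-fold higher number from compound 3 to compound 4 (0.35 log units; beyond the scatter) against phenethyl and a 2.2-fold higher number from compound 2 to compound 4 (0.34 log units; beyond the scatter) against methyl. Phenethyl and methyl had read level in compound 3 and compound 2, so a change here shows up only with anilino among the three groups. No measurement on hand accounts for this difference. As far as these compounds go, whether the gain follows the amide-type nitrogen or the directly attached phenyl ring remains open, and a benzylamino or plain amino group at this carbonyl would bear on it. Also open, from the compounds shown here alone, is whether anilino holds its effect with the shorter chain on the oxygen of compound 1.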